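Acetyl on the phenyl ring of compound 2

The source may hold more compounds than are shown below. What is called first, only, known or untested is meant among the compounds shown, and "the series" means these compounds.

In a functional assay on B16-F0 cells (Mus musculus) for inhibition, read by CCK-8 assay, with a stated time of 48 h (on this read-out lower numbers stand for stronger inhibition and higher numbers for weaker inhibition), compound 1 (`Cn1ccc2cc(-c3cc4nccc(-c5ccc(F)cc5)n4n3)ccc21`) gives 4780 nM and compound 2 (`COc1cc(-c2ccnc3cc(-c4ccccc4)nn23)cc(OC)c1OC`) gives 4730 nM. These two values lie within the scatter of each other, so compound 2 stands level with compound 1. Compound 3 (`COc1cc(-c2ccnc3cc(-c4ccc(C(C)=O)cc4)nn23)cc(OC)c1OC`) differs from compound 2 by acetyl in place of hydrogen on an aromatic carbon, para to a large group: acetyl in place of hydrogen on an aromatic carbon. Going by the values given here, no measured pair shows this change. In this assay, only a small move toward lower numbers, not beyond the scatter, is expected: the estimated change is a 1.4-fold lower number from compound 2 to compound 3 (0.13 log units; within the scatter). For compound 3 the estimated value is 3500 nM, with an expected range of 1000 nM to 12000 nM.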

Compound 3, half-maximal inhibitory concentration: 3930 nM
Estimate against measurement, compound 3: 1.1-fold (0.05 log units) below; low and high end bracket the measured number.
By their numbers in this assay, from the lowest: compounds 3, 2 and 1 (each within the scatter of the next).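

In this assay, going by these compounds alone, the change from phenyl to 4-acetylphenyl gives a 1.2-fold lower number from compound 2 to compound 3 (0.08 log units; within the scatter) and is the first single-place step. An acetyl on this aromatic carbon, para to a large group, therefore leaves the number within the scatter of the unsubstituted phenyl. No supporting measurement bears on the reason for this result.

As far as these compounds go, whether an amine or a carboxylic acid on this carbon would move the number beyond the scatter remains open. From the compounds shown here alone, a longer chain in place of the acetyl remains equally open.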